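Replacing propyl with 4-fluorophenyl on the shared core

The source may report more compounds than this note shows. Statements on the series, on what has been measured and on what is new or still open speak of the compounds shown alone.

In a functional assay on CHO cells for antagonist activity at prostaglandin E2 receptor EP4 subtype (Homo sapiens), read by calcium flux, with a stated time of 15 min (a lower number here means a stronger inhibitor, a higher number a weaker inhibitor), compound 1 `CCCc1nnn(Cc2ccc(C(F)(F)F)cc2)c1C(=O)N[C@@H](C)c1ccc(C(=O)O)cc1` gives 68.8 nM. Going by the values given here, compound 2 `COc1ccc(Cn2nnc(-c3ccccc3)c2C(=O)N[C@@H](C)c2ccc(C(=O)O)cc2)cc1OC` gives 119 nM in this assay; the two numbers lie within the usual scatter of each other, and since compound 2 differs from compound 1 in more than one place, no single-point step can be drawn from them. Compound 3 `C[C@H](NC(=O)c1c(-c2ccc(F)cc2)nnn1Cc1ccc(C(F)(F)F)cc1)c1ccc(C(=O)O)cc1` carries 4-fluorophenyl in place of propyl on an aromatic carbon. Among the compounds with values here, no measured step of this kind exists in the set, so the expected step is a 1.0-fold higher number from compound 1 to compound 3 (0.01 log units; within the scatter), not beyond the scatter in either direction. Compound 3 is therefore estimated at 70 nM, with a range from 25 nM to 200 nM.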

Compound 3, half-maximal inhibitory concentration: 57.9 nM
The estimate for compound 3 lay 1.2-fold (0.08 log units) above the measured number; the range from low to high includes it.
By their numbers in this assay, from the lowest: compounds 3, 1 and 2 (each within the scatter of the next, the first and the last beyond it).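

In this assay the swap of propyl for 4-fluorophenyl gives a 1.2-fold lower number from compound 1 to compound 3 (0.07 log units; within the scatter) and so the position on the aromatic carbon of the shared core accepts an aromatic ring as well as a chain, with the two groups reading alike. Going by these compounds alone, the earlier compounds held no single-place step at this position, so this is the only direct reading of it. Nothing measured here bears on why the two groups read alike.

As far as these compounds go, whether an amine, a carboxylic acid or a longer chain at this position would read the same stays open. Also open, from the compounds shown here alone, is whether propyl and 4-fluorophenyl still match with another group in place of the 4-(trifluoromethyl)benzyl group.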